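The source may report more compounds than this note shows. Statements on the series, on what has been measured and on what is new or still open speak of the compounds shown alone.

Measured so far:
compound 1 `O=C(Nc1cccc(-n2cc(-c3ccncc3)c(-c3cc(O)cc(Cl)c3)n2)c1)Nc1ccc(Cl)c(C(F)(F)F)c1`: 18.5%
compound 2 `COc1cc(Cl)cc(-c2nn(-c3cccc(NC(=O)Nc4ccc(Cl)c(C(F)(F)F)c4)c3)cc2-c2ccncc2)c1`: 11.1%

In a functional assay on UO-31 cells (Homo sapiens) for inhibition, read by sulforhodamine B assay, with a stated time of 48 h, tested at 10 uM (a higher number here means a weaker effect of the compound at the concentration tested, a lower number a stronger effect), compound 2 gives 11.1%, while compound 1 gives 18.5%; the step of a number 7.4 percentage points lower from compound 1 to compound 2 (within the scatter) lies within the scatter, so the two compounds stand together rather than apart. Compound 3 `COc1cc(Cl)cc(-c2nn(-c3cccc(NC(=O)Nc4cccc(C(F)(F)F)c4)c3)cc2-c2ccncc2)c1` differs from compound 2 by hydrogen in place of chloro on an aromatic carbon. For the measured compounds named here, no measured step touches this position; the only step available, a number 7.4 percentage points lower from compound 1 to compound 2 (within the scatter), concerns a different site and was within the scatter, so it gives little guidance. Compound 3 is therefore expected to show a step of a number 8.9 percentage points higher from compound 2 to compound 3 (within the scatter) of no clear direction beyond the scatter. Compound 3 is estimated at 20%, within 5% to 45%.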

Compound 3, a percentage reported as activity, at one concentration (the size of the read-out at that concentration, not a potency): -4.59%
The estimate for compound 3 lay 24.6 percentage points above the measured number; measured number outside the range, below it.
By their numbers in this assay, from the lowest: compound 3; then compounds 2 and 1 (each within the scatter of the next).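

In this assay, for the compounds shown here, the change from 4-chloro-3-(trifluoromethyl)phenyl to 3-(trifluoromethyl)phenyl gives a number 15.7 percentage points lower from compound 2 to compound 3 (beyond the scatter) and is the first step here beyond the scatter, towards a stronger effect at the concentration tested. Unlike the oxygen site changed earlier, this position responds, and in this pair the effect does not depend on the chloro. No available evidence accounts for the direction of this step.

As far as these compounds go, whether a fluoro, a methyl or an amine at this position would do the same remains open. So does whether losing the chloro has a like effect in compound 1.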